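Exchanging the aryl amide on the shared core

The source may hold more compounds than are shown below. What is called first, only, known or untested is meant among the compounds shown, and "the series" means these compounds.

Compound 2 `O=C(Nc1cccc(/C=C/C(=O)c2nc3ccccc3[nH]2)c1)c1ccc(Br)cc1` carries a 4-bromophenyl on the amide carbonyl. In a functional assay on 143B cells (Homo sapiens) for antiproliferative activity, read by MTT assay, with a stated time of 48 h (on this read-out higher numbers stand for weaker inhibition and lower numbers for stronger inhibition), compound 2 gives 7310 nM, the highest of the two numbers recorded here. Its nearest neighbour is compound 1 `O=C(/C=C/c1cccc(NC(=O)c2ccccc2Cl)c1)c1nc2ccccc2[nH]1`, which in this assay gives 3690 nM; the step of a 2.0-fold higher number from compound 1 to compound 2 (0.30 log units; within the scatter) swaps 2-chlorophenyl for 4-bromophenyl on the carbonyl carbon and stays within the scatter. Compound 3 `Cc1ccccc1C(=O)Nc1cccc(/C=C/C(=O)c2nc3ccccc3[nH]2)c1` has not yet been measured. It differs from compound 2 by 2-methylphenyl in place of 4-bromophenyl on a carbonyl carbon. For the measured compounds named here, only one measured step bears on a change of this kind, an exchange of the aryl group on the same carbonyl carbon, namely a 2.0-fold higher number from compound 1 to compound 2 (0.30 log units; within the scatter), and it lies within the scatter. The 2-methylphenyl of compound 3 resembles the 2-chlorophenyl of compound 1 more than the 4-bromophenyl of compound 2, so the number for compound 3 is expected to fall somewhat below that of compound 2, yet within the scatter. The expected step is a 1.6-fold lower number from compound 2 to compound 3 (0.21 log units; within the scatter). The estimate for compound 3 in this assay is 4500 nM, with a range from 1800 nM to 11000 nM.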

Compound 3, half-maximal inhibitory concentration: 8290 nM
The estimate for compound 3 lay 1.8-fold (0.27 log units) below the measured number, within the range that was stated.
By their numbers in this assay, from the lowest: compounds 1, 2 and 3 (each within the scatter of the next, the first and the last beyond it).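

In this assay, the exchange on the carbonyl carbon can now be read a second time, and a 1.1-fold higher number from compound 2 to compound 3 (0.05 log units; within the scatter) shows that 2-methylphenyl and 4-bromophenyl cannot be told apart here, although they differ both in the substituent and in its numbered place on the phenyl. For the compounds shown here, the pair sharing that numbered place does separate, since a 2.2-fold higher number from compound 1 to compound 3 (0.35 log units; beyond the scatter) for methyl in place of chloro on an aromatic carbon is the only step of the three beyond the scatter, and it is modest. Sharing the numbered place therefore did not keep two compounds together, and as compound 2 lies within the scatter of both others, only compound 1 and compound 3 can be put in an order.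

From the compounds shown here alone, all three compounds carry a singly substituted phenyl on this carbonyl carbon, so it remains open whether an amine or a carboxylic acid on that phenyl, or a longer chain in its stead, would shift the number further than these steps do. No measurement at hand offers an explanation for the separation of compound 1 and compound 3.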